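This account rests on a few compounds, and the source may have more. Where it says the series, first, only, none or still open, it means among the compounds named here.

Compound 1 `C[C@H]1[C@H](NCc2ccoc2)C[C@H]2C[C@@H]1C2(C)C` stands in an ADME assay on MDCK cells (Canis lupus familiaris) for cytotoxicity, read by microscopy, with a stated time of 48 h (a higher number here means that more compound is tolerated, a lower number that less compound is tolerated), at > 100000 nM, and this is a limit of the assay rather than a measured number. Compound 2 `C[C@H]1[C@H](NCc2ccc(C(C)(C)C)s2)C[C@H]2C[C@@H]1C2(C)C` gives 780 nM in this assay, and compound 3 `C[C@H]1[C@H](NCc2sccc2C2CC2)C[C@H]2C[C@@H]1C2(C)C` gives 25000 nM. Compound 4 `Cc1n[nH]cc1CN[C@@H]1C[C@H]2C[C@@H]([C@H]1C)C2(C)C` has not yet been tested in this assay; it differs from compound 1 by 3-methyl-1H-pyrazol-4-yl in place of furan-3-yl on a saturated chain carbon bound to an amine nitrogen. Going by the values given here, no pair of measured compounds here differs in only one place, so no measured step gives a size for this kind of change. For compound 4 the step of a number no higher from compound 1 to compound 4 (the limit leaves the size open) is expected to stay within the scatter, given that compound 1 sits at the limit of > 100000 nM in this assay, at which 1 of the 3 values shown sits. Compound 4 is therefore estimated at 100000 nM, in a range from 40000 nM to 300000 nM.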

Compound 4, minimum cytotoxic concentration: > 100000 nM
Compound 4 ended at the assay's limit; the forecaster's own chance of this, stated with the estimate: 60%; the middle value sits exactly at the limit.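

No step can be read between compound 1 and compound 4, as each stands at a limit and not at a measured number: the limit of > 100000 nM in this assay, at which 2 of the 4 values shown sit. The compounds shown leave open how far 3-methyl-1H-pyrazol-4-yl in place of furan-3-yl shifts the tolerated concentration in this assay.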